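Terminal group on the long chain of compound 3

A few compounds are considered here, and "the series" means these few. Any claim that something is new, unique, unknown or untested is made for them only; others in the source may bear on it.

Working notes on a three-membered set sharing one core and differing only in the chain on one aryl oxygen. Compound 1 is `CCC(CC)(c1ccc(OCC(O)CO)c(C)c1)c1ccc(OCC(O)C(C)(C)C)c(OCC(O)C(C)(C)C)c1`, compound 2 is `CCC(CC)(c1ccc(OCCCCO)c(C)c1)c1ccc(OCC(O)C(C)(C)C)c(OCC(O)C(C)(C)C)c1` and compound 3 is `CCC(CC)(c1ccc(OCCCCCCCO)c(C)c1)c1ccc(OCC(O)C(C)(C)C)c(OCC(O)C(C)(C)C)c1`. In an assay on cells for binding affinity to vitamin D3 receptor (Homo sapiens), read by fluorescence, tested at 1 uM (on this read-out higher numbers stand for more inhibition at the one concentration tested (going by the name of the read-out) and lower numbers for less inhibition), compound 1 gives 78%. In this assay compound 2 gives 71%, and compound 3 gives 5%. The two short-chain compounds sit close together, a number 7 percentage points lower from compound 1 to compound 2 (within the scatter), whereas the longer chain of compound 3 falls far off: a number 73 percentage points lower from compound 1 to compound 3 (beyond the scatter) and a number 66 percentage points lower from compound 2 to compound 3 (beyond the scatter). Compound 3 is thus the lowest of the three, with both neighbours beyond the scatter above it.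

Compound 4, `CCC(CC)(c1ccc(OCCCCCCC(=O)O)c(C)c1)c1ccc(OCC(O)C(C)(C)C)c(OCC(O)C(C)(C)C)c1`, keeps the long chain of compound 3 and alters only its end: carboxy in place of hydroxymethyl on a saturated chain carbon, six bonds along the chain from an oxygen on an aromatic ring. Among the compounds with values here, no measured step swaps the terminal group at a fixed chain length; the two steps that do bear on compound 3 concern chain length alone and both point to the long chain carrying the loss. With the chain length unchanged, no step beyond the scatter is expected, a number 5 percentage points higher from compound 3 to compound 4 (within the scatter). Compound 4 is therefore expected to give about 10% in this assay, in a range of -8% to 32%.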

Compound 4, a percentage reported as inhibition, at one concentration (the size of the read-out at that concentration, not a potency): "not active" (no number reported)
For compound 4 the study gives words and no number; no gap can be computed for the estimate.
By their numbers in this assay, from the lowest: compound 3; then compounds 2 and 1 (each within the scatter of the next).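

In this assay, within the data shown here, compound 4 is reported only as "not active", without a number, so no step from compound 3 to compound 4 can be read. The compounds shown leave open whether carboxy in place of hydroxymethyl at this chain length shifts the read-out at all. No supporting data bear on this result.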